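A few compounds are considered here, and "the series" means these few. Any claim that something is new, unique, unknown or untested is made for them only; others in the source may bear on it.

In an ADME assay on J774 cells (Mus musculus) for antiproliferative activity, with a stated time of 72 h (a lower number here means that less compound is needed, a higher number that more compound is needed for the effect), three compounds of a shared core have been measured. Compound 1 `COC(=O)c1c[nH]c2cc(OC)c(Cl)cc2c1=O` gives 37000 nM. Compound 2 `CCc1c(C)[nH]c2cc(OCCOc3ccccc3)c(OC)cc2c1=O` reaches only a limit of the measurement, > 29000 nM, which is the limit of > 29000 nM in this assay, at which 1 of the 3 values shown sits. Compound 3 `CCCCc1cc2c(=O)c(-c3ccccc3)c(C)[nH]c2cc1OCCOc1ccccc1` gives 23000 nM, the lower of the two plain numbers shown, yet its gap to compound 1 lies within the usual scatter, so the two cannot be set apart.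

Compound 4 `CCCCc1cc2c(=O)c(-c3ccc(Cl)cc3C)c(C)[nH]c2cc1OCCOc1ccccc1` differs from compound 3 in one place: 4-chloro-2-methylphenyl in place of phenyl on an aromatic carbon. Among the compounds with values here, no pair of measured compounds shows a step of this kind, so any direction rests on expectation alone. The expected step is small, a 1.5-fold lower number from compound 3 to compound 4 (0.19 log units; within the scatter), toward a lower number if anywhere, and not clearly beyond the scatter. Compound 4 is therefore expected in this assay at about 15000 nM, within a range from 5000 nM to 45000 nM.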

Compound 4, half-maximal effective concentration: > 21000 nM
Compound 4 was reported as a limit (the forecaster's own chance of this, stated with the estimate: 25%); at least 1.4-fold (0.14 log units) between middle value and limit.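

In this assay compound 4 gives only a limit, > 21000 nM and so no step can be read between compound 3 and compound 4. The compounds shown leave open whether 4-chloro-2-methylphenyl in place of phenyl changes the number at all.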